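From pyrrolidin-1-yl to piperazin-1-yl on a shared core

The compounds below may be only part of what the source reports. "The series", "measured", "known", "first", "only" and "open" are said of these compounds alone.

Measured in a functional assay on V79 cells (Cricetulus griseus) for cytotoxicity, read by colony formation; on this read-out lower numbers stand for stronger inhibition and higher numbers for weaker inhibition:
- compound 1 `O=C(O)c1cn(C2CC2)c2c(F)c(N3CCCC3)c(F)cc2c1=O`: 120 ug/mL
- compound 2 `COc1c(N2CCCC2)c(F)cc2c(=O)c(C(=O)O)cn(C3CC3)c12`: 150 ug/mL
- compound 3 `O=C(O)c1cn(C2CC2)c2c(C(F)(F)F)c(N3CCCC3)c(F)cc2c1=O`: 280 ug/mL

Compound 2, at 150 ug/mL, lies within the scatter of both other compounds, as a 1.3-fold higher number from compound 1 to compound 2 (0.10 log units; within the scatter) and a 1.9-fold higher number from compound 2 to compound 3 (0.27 log units; within the scatter) show. Only a 2.3-fold higher number from compound 1 to compound 3 (0.37 log units; beyond the scatter) goes beyond the scatter, and that step is modest.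

Compound 4 `COc1c(N2CCNCC2)c(F)cc2c(=O)c(C(=O)O)cn(C3CC3)c12` has piperazin-1-yl in place of pyrrolidin-1-yl on an aromatic carbon. Within the data shown here, none of the measured steps makes this exchange. All three swap fluoro, methoxy and trifluoromethyl while pyrrolidin-1-yl stays, so they bear on it only indirectly, by showing how far the numbers have moved so far. Among the measured compounds shown here, the data hold no direct precedent for the new group, so the range must stay wide. In this assay no change beyond the scatter is expected, and no direction is favoured. The expected step is a 1.2-fold higher number from compound 2 to compound 4 (0.08 log units; within the scatter). For compound 4 the estimated value is 180 ug/mL, with an expected range from 70 ug/mL to 450 ug/mL.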

Compound 4, half-maximal inhibitory concentration: 82 ug/mL
The estimate for compound 4 lay 2.2-fold (0.34 log units) above the measured number; low and high end bracket the measured number.
By their numbers in this assay, from the lowest: compounds 4, 1, 2 and 3 (each within the scatter of the next, the first and the last beyond it).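

In this assay, among these compounds, the exchange of pyrrolidin-1-yl for piperazin-1-yl gives a 1.8-fold lower number from compound 2 to compound 4 (0.26 log units; within the scatter), the first reading of this place on the shared core, since the earlier steps varied only the fluoro, methoxy and trifluoromethyl groups. With methoxy and fluoro as its ortho neighbours, this aromatic carbon thus accepts a six-membered ring with a second ring nitrogen and a hydrogen-bond donor without a step beyond the scatter on this read-out. Nothing available on the compounds' properties bears on this result.

The piperazin-1-yl group is shown here only alongside methoxy, so whether it would behave the same with fluoro or trifluoromethyl in that place remains open. Also open, on these data alone, is how a morpholine ring, or a methyl group on the outer nitrogen of piperazin-1-yl, would read in this assay.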